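Chloro for Fluoro in Two Spiro Series at the Limit

The source may hold more compounds than are shown below. What is called first, only, known or untested is meant among the compounds shown, and "the series" means these compounds.

Compound 1 `N#CC1=C(N)Oc2c(c3nc4ccccc4nc3c3ccccc23)C12C(=O)N(Cc1cnnn1-c1ccc(F)cc1)c1ccccc12` carries a 1-(4-fluorophenyl)-1H-1,2,3-triazol-5-yl group. In a functional assay on A549 cells (Homo sapiens) for antiproliferative activity, read by MTT assay, with a stated time of 48 h (a higher number here means a weaker inhibitor, a lower number a stronger inhibitor), compound 1 gives > 50000 nM, which is a limit of the assay rather than a number. Compound 2 `N#CC1=C(N)Oc2c(c3nc4ccccc4nc3c3ccccc23)C12C(=O)N(Cc1cnnn1-c1ccc(Cl)cc1)c1ccccc12` differs from it by chloro in place of fluoro on an aromatic carbon. In this assay compound 2 gives > 50000 nM, again only a limit. The step that the two limits leave unreadable from compound 1 to compound 2 therefore cannot be read. Compound 3 `N#CC1=C(N)Oc2c(N)cc3nc4ccccc4nc3c2C12C(=O)N(Cc1cnnn1-c1ccc(F)cc1)c1ccccc12` has a different core; the difference between the two cores is not broken down here. In this assay compound 3 gives > 50000 nM, once more a limit. Compound 4 `N#CC1=C(N)Oc2c(N)cc3nc4ccccc4nc3c2C12C(=O)N(Cc1cnnn1-c1ccc(Cl)cc1)c1ccccc12`, still to be measured, differs from compound 3 by chloro in place of fluoro on an aromatic carbon, the same change as between the first two. Because (the limit of > 50000 nM in this assay, at which 3 of the 3 values shown sit), compound 4 is expected to stay at that limit too, so the expected step that the limit leaves unreadable from compound 3 to compound 4 is small. Compound 4 is therefore estimated at 60000 nM.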

Compound 4, half-maximal inhibitory concentration: > 50000 nM
Compound 4 gave a limit, no number; the forecaster's own chance of this, stated with the estimate: 90%; the middle value lies beyond the limit too.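

Among the compounds shown here, compound 3 and compound 4 both sit at a limit of this assay, not at a number, so no step between them can be read. The compounds shown leave open whether chloro and fluoro differ at all on either core.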